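A few compounds are considered here, and "the series" means these few. Any claim that something is new, unique, unknown or untested is made for them only; others in the source may bear on it.

Of the compounds shown here, two have so far been measured in a physicochemical assay for solubility, read by nephelometry, in phosphate buffer, measured as kinetic solubility, at pH 6.5; on this read-out higher numbers stand for higher solubility and lower numbers for lower solubility. Compound 1 `COc1ccc(-c2cc(-c3ccc(NS(C)(=O)=O)cc3)cnc2N)cn1` gives 25 ug/mL. Compound 2 `COc1ccc(-c2cc(-c3ccc(C(N)=O)cc3)cnc2N)cn1` gives 12.5 ug/mL. Within the data shown here, the only step between them is a 2.0-fold lower number from compound 1 to compound 2 (0.30 log units; within the scatter), so the two numbers cannot be told apart, and compound 2 simply stands beside compound 1 on this assay. Compound 3 `CNC(=O)c1ccc(-c2cnc(N)c(-c3ccc(OC)nc3)c2)cc1` differs from compound 2 by methyl in place of hydrogen on an amide-type nitrogen. Among the measured compounds shown here, no measured step bears on this change: the one step known swaps one whole group for another on the aromatic ring, and none replaces a hydrogen on an amide-type nitrogen with a methyl. With nothing to point either way, the expected step of no change at the digits printed from compound 2 to compound 3 (within the scatter) is none beyond the scatter, and the estimate is drawn simply from where compound 2 stands. Compound 3 is therefore estimated at 12.5 ug/mL, with a range from 5 ug/mL to 30 ug/mL.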

Compound 3, solubility: 50 ug/mL
Compound 3: middle estimate off by 4.0-fold (0.60 log units), on the low side; the whole stated range lies below it.
By their numbers in this assay, from the lowest: compounds 2, 1 and 3 (each within the scatter of the next, the first and the last beyond it).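

The amide nitrogen of the carbamoyl group proves to be a place where one added carbon registers on this assay: methyl in place of the amide hydrogen gives a 4.0-fold higher number from compound 2 to compound 3 (0.60 log units; beyond the scatter), the only step shown that clears the scatter. The exchange of whole groups gives less to read: methylcarbamoyl in place of methanesulfonamido gives a 2.0-fold higher number from compound 1 to compound 3 (0.30 log units; within the scatter), so compound 1 and compound 3 cannot be told apart on this read-out. Nothing measured here accounts for the methyl step.

Going by these compounds, whether the step belongs to methyl alone stays open, since an ethyl, a longer chain or a second methyl on that nitrogen could follow it or not. The compounds shown also do not tell how a carboxylic acid or an amine would read at the same place on the aromatic ring.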